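One Trifluoromethyl on the Phenyl of Compound 3

This account rests on a few compounds, and the source may have more. Where it says the series, first, only, none or still open, it means among the compounds named here.

Measured compounds:
compound 1, `COc1cc2c(Oc3ccc(NC(=O)c4nnn(-c5ccccc5C)c4C)cc3F)ccnc2cc1OCCCN1CCCC1`, 720 nM;
compound 2, `COc1cc2c(Oc3ccc(NC(=O)c4nnn(-c5ccccc5C(F)(F)F)c4C(F)(F)F)cc3F)ccnc2cc1OCCCN1CCCC1`, 270 nM;
compound 3, `COc1cc2c(Oc3ccc(NC(=O)c4nnn(-c5ccccc5C)c4C)cc3F)ccnc2cc1OCCCN1CCCCC1`, 780 nM.

In a functional assay on NCI-H460 cells (Homo sapiens) for cytotoxicity, read by MTT assay, with a stated time of 72 h (a lower number here means a stronger inhibitor, a higher number a weaker inhibitor), compound 3 gives the highest of the three numbers. Compound 1 stands nearest, and the step of a 1.1-fold higher number from compound 1 to compound 3 (0.03 log units; within the scatter) lies within the scatter. Compound 2 differs from compound 1 in two places rather than one; in this assay compound 2 gives 270 nM, a number well below that of compound 3.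

Compound 4, `COc1cc2c(Oc3ccc(NC(=O)c4nnn(-c5ccccc5C(F)(F)F)c4C)cc3F)ccnc2cc1OCCCN1CCCCC1`, differs from compound 3 by one change: trifluoromethyl in place of methyl on an aromatic carbon. Going by the values given here, no measured step covers exactly this single change. Among the compounds with values here, the only guide is the pair of compound 1 and compound 2, where the number falls beyond the scatter, but that pair carries the change at two places at once. For a change at one place a smaller drop is expected, and compound 4 is estimated at 480 nM, with a range from 220 nM to 1000 nM. The expected step is a 1.6-fold lower number from compound 3 to compound 4 (0.21 log units; within the scatter), likely near the edge of the scatter.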

Compound 4, half-maximal inhibitory concentration: 280 nM
For compound 4 the middle estimate is 1.7-fold (0.23 log units) above the measured one; the measured number falls inside the stated range.
By their numbers in this assay, from the lowest: compounds 2 and 4 (each within the scatter of the next); then compounds 1 and 3 (each within the scatter of the next).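

In this assay, trifluoromethyl in place of methyl on an aromatic carbon, ortho to a large group, gives a 2.8-fold lower number from compound 3 to compound 4 (0.44 log units; beyond the scatter) and so moves the number beyond the scatter as a single change. The earlier compounds shown here showed this replacement only alongside a second one, in the pair of compound 1 and compound 2, so they could not tie any shift to this position alone. No measurement shown here explains why 2-(trifluoromethyl)phenyl gives the lower number.

On these data alone, whether chlorine, methoxy or ethyl in the same place would lower the number as well remains open. As far as these compounds go, it is also open whether the same replacement gives a step of similar size with the pyrrolidin-1-yl group of compound 1 in place of the piperidin-1-yl group of compound 3.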